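The compounds below may be only part of what the source reports. "The series", "measured", "known", "first", "only" and "open" are said of these compounds alone.

Measured so far:
compound 1 `N#Cc1c(Cl)nc(SCC(=O)Nn2c(COc3ccc(Cl)cc3Cl)nc3ccccc3c2=O)nc1-c1ccccc1` — 68.4%
compound 2 `N#Cc1c(Nc2ccc(Cl)cc2)nc(SCC(=O)Nn2c(COc3ccc(Cl)cc3Cl)nc3ccccc3c2=O)nc1-c1ccccc1` — 59.7%

In a functional assay on the whole organism (strain albino) for inhibition, with Rattus norvegicus as the target, read by paw edema, with stated times of 1 h and 3 h, at a dose of 100 mg/kg by the oral route (on this read-out higher numbers stand for a stronger effect at the one dose given and lower numbers for a weaker effect), compound 2 gives 59.7%, and compound 1 gives 68.4%. For the measured compounds named here, the one step measured, a number 8.7 percentage points lower from compound 1 to compound 2 (within the scatter), lies within the scatter, so the two compounds are not separated by these numbers.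

Compound 3 `N#Cc1c(Nc2ccc(O)cc2)nc(SCC(=O)Nn2c(COc3ccc(Cl)cc3Cl)nc3ccccc3c2=O)nc1-c1ccccc1` differs from compound 2 by hydroxy in place of chloro on an aromatic carbon. Going by the values given here, no measured step bears directly on this exchange; the only step available, a number 8.7 percentage points lower from compound 1 to compound 2 (within the scatter), concerns a different change and was itself within the scatter. The series therefore gives no evidence of a sizeable shift for the present change, and the step of a number 1.7 percentage points lower from compound 2 to compound 3 (within the scatter) is expected to stay within the scatter. In this assay compound 3 is expected to give 58%, with a range from 44% to 72%.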

Compound 3, a percentage reported as inhibition, in the whole organism at one dose (the size of the read-out at that dose, not a potency): 59.7%
Beside the measured number, compound 3's estimate is 1.7 percentage points below it, and the stated range covers the measured number.
By their numbers in this assay, from the lowest: compounds 2, 3 and 1 (each within the scatter of the next).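

In this assay, the change from 4-chlorophenyl to 4-hydroxyphenyl gives no change at the digits printed from compound 2 to compound 3 (within the scatter) and so brings in a hydrogen-bond donor and acceptor, where chloro has neither, without separating the two compounds. Replacing chloro on the aromatic carbon of the shared core with (4-hydroxyphenyl)amino gives a number 8.7 percentage points lower from compound 1 to compound 3 (within the scatter) and thus leaves all three compounds within the scatter of one another at the one dose given. No accompanying data offer an explanation for these numbers.

Going by these compounds, it remains open whether a methoxy, an amino or a carboxylic acid group in the same place on the phenyl ring would stand apart from chloro and hydroxy. Also open, on these data alone, is whether a morpholine or a simple alkylamine in place of the arylamino group would separate from these compounds.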